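The source may report more compounds than this note shows. Statements on the series, on what has been measured and on what is new or still open speak of the compounds shown alone.

Working notes on the series.

The series shares the core of compound 2 `Oc1ccccc1CNc1ccc(-c2ccccc2)cc1`, which in a functional assay on Jurkat cells (Homo sapiens) for activation, with a stated time of 24 h (a higher number here means that more compound is needed for the effect, a lower number that less compound is needed), gives 1820 nM. Compound 1 `CN1CCN(c2ccc(NCc3ccccc3O)cc2)CC1` carries a different group at the same end of the core and in this assay compound 1 is reported as "not active" (no number reported), with no number. Compound 3 `Oc1ccccc1CNc1ccc(-c2ccc(F)cc2)cc1` in this assay gives 3860 nM. Of the two numbers in hand, compound 3 holds the higher one; the step of a 2.1-fold higher number from compound 2 to compound 3 (0.33 log units; beyond the scatter) is beyond the scatter but modest.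

Compound 4 `Cc1cccc(-c2ccc(NCc3ccccc3O)cc2)c1` differs from compound 3 by 3-methylphenyl in place of 4-fluorophenyl on an aromatic carbon. Going by the values given here, the only measured step on this end of the core, a 2.1-fold higher number from compound 2 to compound 3 (0.33 log units; beyond the scatter), concerns a fluorine put onto the distal ring, not a methyl, and it moved the number by a modest amount. Among the compounds with values here, there is no measured pair that swaps a substituent on that ring for another, so the bearing of that step on the change to compound 4 is indirect. The expectation is therefore a small step, a 1.5-fold lower number from compound 3 to compound 4 (0.19 log units; within the scatter), toward the lower number of compound 2 1820 nM rather than a large move in either direction. For compound 4 the estimate in this assay is 2500 nM, within a range from 900 nM to 7000 nM.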

Compound 4, half-maximal effective concentration: 9190 nM
For compound 4 the middle estimate is 3.7-fold (0.57 log units) below the measured one; the measured number lies above the stated range.
By their numbers in this assay, from the lowest: compound 2; then compound 3; then compound 4.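

Notes on the phenyl group at this end of the core: in this assay, the 3-methylphenyl group of compound 4 stands further from the unsubstituted phenyl group than the 4-fluorophenyl group of compound 3 does, with methyl in place of hydrogen giving the larger step (a 5.0-fold higher number from compound 2 to compound 4 (0.70 log units; beyond the scatter)) and fluoro in place of hydrogen the smaller (a 2.1-fold higher number from compound 2 to compound 3 (0.33 log units; beyond the scatter)). The direct swap is also beyond the scatter (a 2.4-fold higher number from compound 3 to compound 4 (0.38 log units; beyond the scatter)), so among these three compounds both substituents raise the number, and compound 2 keeps the lowest value, with neither substituted compound going against that order. The swap changes the substituent and its place on the ring together, so the size of this step cannot be assigned to either change alone. Nothing in hand accounts for these differences.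

Still open, from the compounds shown here alone, is whether a 4-methylphenyl or a 3-fluorophenyl group would separate the effect of the substituent from that of its place. Also open, going by these compounds, is whether a nitrile or a carboxylic acid on this ring would bring the number below that of compound 2 (1820 nM) rather than above it.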